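The compounds below may be only part of what the source reports. "The series", "measured", "known", "first", "only" and "open" are said of these compounds alone.

Measured compounds:

Compound 1, `O=C(COc1cc(Cl)ccc1Cl)N/N=C/c1ccc[nH]1`: 3390 nM
Compound 2, `CC(Oc1cc(Cl)ccc1Cl)C(=O)N/N=C/c1ccc[nH]1`: 33400 nM
Compound 3, `O=C(COc1ccc(F)cc1Cl)N/N=C/c1ccc[nH]1`: 8860 nM

The three compounds were tested in a functional assay (Homo sapiens) for inhibition; a higher number here means that more compound is needed for the effect, a lower number that less compound is needed. Compound 1 gives 3390 nM in this assay, while compound 2, which carries the change (methyl in place of hydrogen on a saturated chain carbon bound to a carbonyl carbon and an oxygen on an aromatic ring), gives 33400 nM. That single change accounts for a 9.9-fold higher number from compound 1 to compound 2 (0.99 log units; beyond the scatter). Compound 3, which has a different core, gives 8860 nM in this assay; the difference between the core of compound 3 and the core of compound 1 is not broken down here, and what can be said is that compound 3 sits between compound 1 and compound 2, the gaps to both lying beyond the scatter.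

Compound 4, `CC(Oc1ccc(F)cc1Cl)C(=O)N/N=C/c1ccc[nH]1`, has not yet been measured in this assay. It stands to compound 3 as compound 2 stands to compound 1: the change is methyl in place of hydrogen on a saturated chain carbon bound to a carbonyl carbon and an oxygen on an aromatic ring, and the place is described in the same words in both pairs, so this is the same change made on a second core. For the measured compounds named here, since the one earlier example of this change weakened the compound, the expectation for compound 4 is a step of about a 7.9-fold higher number from compound 3 to compound 4 (0.90 log units; beyond the scatter), resting on the size of the step from compound 1 to compound 2. Going by the values given here, on that basis compound 4 is estimated at 70000 nM in this assay, with a plausible span from 20000 nM to 250000 nM; with only one prior instance of the change, that span is kept wide.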

Compound 4, half-maximal effective concentration: 35400 nM
Estimate against measurement, compound 4: 2.0-fold (0.30 log units) above, within the range that was stated.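

In this assay, methyl in place of hydrogen on the saturated chain carbon bound to the carbonyl carbon and the aromatic-ring oxygen gives a 4.0-fold higher number from compound 3 to compound 4 (0.60 log units; beyond the scatter), so on the second core the change again raises the number, as it did on the first. Set side by side, the two steps point the same way and their sizes do not differ beyond what repeated measurement allows: the same change on two cores in this assay, a 9.9-fold higher number (0.99 log units; beyond the scatter) from compound 1 to compound 2 and a 4.0-fold higher number (0.60 log units; beyond the scatter) from compound 3 to compound 4, 2.5-fold (0.39 log units) apart, within the scatter of two such steps This shows that, across these two cores, the change carried over in direction and, within the scatter, in size; it does not show that the step on the second core is truly smaller than the one on the first, that the change would behave alike on any further core, or why the number rises at all.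

The compounds shown leave open whether a larger group at the same carbon, such as ethyl, or a group of another kind there, such as a hydroxyl or an amine, would raise the number as methyl does. They also leave open whether the step would hold with something other than halogens on the aromatic ring, such as a methoxy group or a nitrile.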